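Aryl-piperazine amides: swap toward 3-acetamidophenyl

The source may hold more compounds than are shown below. What is called first, only, known or untested is meant among the compounds shown, and "the series" means these compounds.

Three compounds of the series have numbers in a functional assay on HL-60 cells (Homo sapiens) for inhibition, read by MTT assay, with a stated time of 72 h; on this read-out higher numbers stand for weaker inhibition and lower numbers for stronger inhibition. Compound 1 `CCc1nc(-c2ccccc2F)c(C(=O)N2CCN(c3cccc(Cl)c3)CC2)o1` gives 139 nM in this assay. Compound 2 `Cc1nc(-c2ccccc2F)c(C(=O)N2CCN(c3cc(Cl)cc(Cl)c3)CC2)s1` gives 157 nM. Compound 3 `Cc1ccc(N2CCN(C(=O)c3oc(C)nc3-c3ccccc3)CC2)c(C)c1` gives 101 nM, the lowest of the three numbers, though its gaps to compound 1 and to compound 2 both sit within the scatter, so the three read as alike rather than ordered. Going by the values given here, no pair among them differs in a single place, so no counted step between measured compounds is available.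

The next compound, compound 4 `CC(=O)Nc1cccc(N2CCN(C(=O)c3oc(C)nc3-c3ccccc3)CC2)c1`, keeps the shared core of compound 3 and changes the group on the ring nitrogen: 3-acetamidophenyl in place of 2,4-dimethylphenyl on an amine nitrogen in a ring. Among the compounds with values here, the series holds no measured pair that isolates a change of this kind on that nitrogen, so the step in this assay cannot be read off from anything measured; it is a guess from the three numbers alone, which all fall in one narrow band.

The working expectation is a small step toward weaker inhibition, close to the edge of the scatter, with the number for compound 4 estimated at 250 nM, between 80 nM and 800 nM. That estimate means a step of a 2.5-fold higher number from compound 3 to compound 4 (0.39 log units; beyond the scatter), which is expected and not measured.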

Compound 4, half-maximal inhibitory concentration: 329 nM
Estimate against measurement, compound 4: 1.3-fold (0.12 log units) below; measured number inside the range.
By their numbers in this assay, from the lowest: compounds 3, 1 and 2 (each within the scatter of the next); then compound 4.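

Going by these compounds alone, this is the first counted step at this position: in this assay, 3-acetamidophenyl in place of 2,4-dimethylphenyl on the amine nitrogen in the ring gives a 3.3-fold higher number from compound 3 to compound 4 (0.51 log units; beyond the scatter). With the core of compound 3 held fixed, the read-out therefore responds to the group on this nitrogen, which the three earlier numbers, all within the scatter of one another, could not show. The swap changes several things at once, since the entering group carries a hydrogen-bond donor, a hydrogen-bond acceptor and a double bond outside the aromatic ring, and nothing at hand gives a reason for the step.

Within the data shown here, the single step cannot say whether the weaker inhibition goes with the acetamide or with the loss of the methyl groups, a question that a plain phenyl, a 3-aminophenyl or a 3-carboxyphenyl on this nitrogen would bear on. On these data alone, whether the same swap gives a step of similar size on the cores of compound 1 and compound 2 also stays open.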